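The compounds below may be only part of what the source reports. "The series", "measured", "known", "first", "only" and "open" are said of these compounds alone.

Compounds measured so far:
- Compound 1 `O=C(NCc1ccccc1)Oc1ccc(Cl)cc1C(=O)Nc1ccc(F)cc1`: 34200 nM
- Compound 2 `O=C(NCc1ccccc1)Oc1ccc(Cl)cc1C(=O)Nc1ccc(Cl)cc1`: 6400 nM
- Compound 3 `O=C(Nc1ccccc1)Oc1ccc(Cl)cc1C(=O)Nc1ccc(Br)cc1`: 5450 nM

In an ADME assay on HepG2 cells (Homo sapiens), read by MTT assay, with a stated time of 72 h, in the presence of a further agent that is not named here (on this read-out higher numbers stand for weaker inhibition and lower numbers for stronger inhibition), compound 3 gives 5450 nM. That is level, within the usual scatter, with compound 2 and clearly lower than compound 1.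

Compound 4 `O=C(NCc1ccccc1)Oc1ccc(Cl)cc1C(=O)Nc1ccc(Br)cc1` differs from compound 3 as follows: benzyl in place of phenyl on an amide-type nitrogen. In short, benzyl replaces phenyl on an amide-type nitrogen. For the measured compounds named here, no measured pair isolates this swap. Going by the values given here, the only measured step, a 5.3-fold lower number from compound 1 to compound 2 (0.73 log units; beyond the scatter), is chloro in place of fluoro on an aromatic carbon, so it bears on the swap only indirectly. Compound 2 already carries the benzyl and gives 6400 nM, so no large change seems likely. The expected result is a 1.1-fold lower number from compound 3 to compound 4 (0.04 log units; within the scatter), which means no shift beyond the scatter. For compound 4 the estimated value is 5000 nM, with an expected range from 2000 nM to 12000 nM.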

Compound 4, half-maximal inhibitory concentration: 1650 nM
Compound 4: middle estimate off by 3.0-fold (0.48 log units), on the high side; measured number below the stated range.
By their numbers in this assay, from the lowest: compound 4; then compounds 3 and 2 (each within the scatter of the next); then compound 1.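

On the amide-type nitrogen, benzyl in place of phenyl does matter when the bromo stays fixed: in this assay there is a 3.3-fold lower number from compound 3 to compound 4 (0.52 log units; beyond the scatter) here. With benzyl held fixed, the halogen on the aromatic carbon also counts, giving a 3.9-fold lower number from compound 2 to compound 4 (0.59 log units; beyond the scatter) for bromo in place of chloro and a 21-fold lower number from compound 1 to compound 4 (1.32 log units; beyond the scatter) for bromo in place of fluoro. No measurement here explains either effect. As far as these compounds go, whether phenethyl on that nitrogen or iodo in place of the bromo would lower the number further stays open. So does whether benzyl has the same effect alongside chloro or fluoro.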